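The source may report more compounds than this note shows. Statements on the series, on what has been measured and on what is new or still open speak of the compounds shown alone.

Series of diaryl ureas on the shared core, measured in an assay on isolated protein for inhibition of serine/threonine-protein kinase TNNI3K (Homo sapiens); on this read-out lower numbers stand for stronger inhibition and higher numbers for weaker inhibition. Compound 1 `CNc1cc(Oc2ccc(NC(=O)Nc3cccc(CF)c3)cc2)ncn1` gives 400 nM. Compound 2 `C[C@@H](O)CNc1cc(Oc2ccc(NC(=O)Nc3cccc(C(F)(F)F)c3)cc2)ncn1` gives 63 nM, the second highest of the three numbers: compound 3 `CNc1cc(Oc2ccc(NC(=O)Nc3cccc(C(F)(F)F)c3)c(F)c2F)ncn1` sits nearest and gives 20 nM, a lower number whose gap from compound 2 lies outside the usual scatter, while compound 1 stands furthest, with a higher number beyond the scatter. Compound 4 `CC(C)(O)CNc1cc(Oc2ccc(NC(=O)Nc3cccc(C(F)(F)F)c3)cc2)ncn1` is the next member and has not been measured. Its change from compound 2 is 1-hydroxy-1-methylethyl in place of 1-hydroxyethyl on a saturated chain carbon bound to a nitrogen on an aromatic ring. Among the measured compounds shown here, no measured pair in this set isolates such a change, so the size of the step is open; the expectation is a step from compound 2 to compound 4 of a 1.1-fold higher number from compound 2 to compound 4 (0.05 log units; within the scatter), not clearly beyond the scatter in either direction. For compound 4 the estimate is 70 nM, with a range from 30 nM to 160 nM.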

Compound 4, half-maximal inhibitory concentration: 40 nM
For compound 4 the middle estimate is 1.8-fold (0.24 log units) above the measured one; the range from low to high includes it.
By their numbers in this assay, from the lowest: compounds 3, 4 and 2 (each within the scatter of the next, the first and the last beyond it); then compound 1.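

In this assay, 1-hydroxy-1-methylethyl in place of 1-hydroxyethyl on a saturated chain carbon bound to a nitrogen on an aromatic ring gives a 1.6-fold lower number from compound 2 to compound 4 (0.20 log units; within the scatter), so this position tolerates the larger group and the loss of the defined stereocentre with no step beyond the scatter. Nothing available explains this step.

Open, going by these compounds, is how an amine or a carboxylic acid in place of the hydroxy group on this chain would read in this assay. Also open, on these data alone, is whether the same change gives a similar step with the other substituents of compound 3.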